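A few compounds are considered here, and "the series" means these few. Any claim that something is new, unique, unknown or untested is made for them only; others in the source may bear on it.

Compound 1, `O=C(Cn1cnc2scc(-c3ccc(Cl)cc3)c2c1=O)N/N=C/c1ccc(Cl)c([N+](=O)[O-])c1`, gives only a limit in an ADME assay on HEK-293T cells (Homo sapiens) for inhibition, read by MTT assay, with a stated time of 48 h (on this read-out lower numbers stand for stronger inhibition and higher numbers for weaker inhibition), namely > 50000 nM.
Compound 2, `O=C(Cn1cnc2scc(-c3ccccc3)c2c1=O)N/N=C/c1ccc(Cl)c([N+](=O)[O-])c1`, gives only a limit in this assay, namely > 50000 nM.
Compound 3, `Cc1cc(-c2csc3ncn(CC(=O)N/N=C/c4ccc(Cl)c(F)c4)c(=O)c23)ccc1Cl`, gives only a limit in this assay, namely > 50000 nM.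

Compound 2 thus stands at the limit of this assay, and it does so together with every other value shown, since (the limit of > 50000 nM in this assay, at which 3 of the 3 values shown sit). Among the compounds with values here, the one measured step that changes a single place, a step that the two limits leave unreadable from compound 1 to compound 2, cannot be read, as both of its ends are limits. Compound 4, `O=C(Cn1cnc2scc(-c3ccc4ccccc4c3)c2c1=O)N/N=C/c1ccc(Cl)c([N+](=O)[O-])c1`, differs from compound 2 by naphthalen-2-yl in place of phenyl on an aromatic carbon. Within the data shown here, no measured step bears readably on this change: the step from compound 1 to compound 2 tells nothing of its size, and compound 3 has no single-place partner among the others. Because every value sits at the limit, as the limit of > 50000 nM in this assay, at which 3 of the 3 values shown sit, records, no direction can be expected for this assay beyond the scatter, and a limit is the most likely outcome. Compound 4 is therefore estimated at 70000 nM, with a range from 20000 nM to 300000 nM. The step this estimate implies is a step that the limit leaves unreadable from compound 2 to compound 4.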

Compound 4, half-maximal inhibitory concentration: > 50000 nM
Compound 4: a limit, no number; the forecaster's own chance of this, stated with the estimate: 80%; the middle value does not contradict the limit.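

Compound 4, like compound 1 and compound 2, gives only a limit, so no step among these three compounds can be read: the limit of > 50000 nM in this assay, at which 4 of the 4 values shown sit. The compounds shown leave open whether swapping phenyl, 4-chlorophenyl or naphthalen-2-yl changes inhibition at all in this assay.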